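Sulfonamide-to-amine swap on the shared core: cytotoxicity outlook

The source may hold more compounds than are shown below. What is called first, only, known or untested is meant among the compounds shown, and "the series" means these compounds.

Measured compounds:
compound 1 `C[C@@H](Cn1ccc(-c2ccc(C#N)c(Cl)c2)n1)NS(=O)(=O)c1cccnc1` — > 30000 nM
compound 2 `C[C@@H](Cn1ccc(-c2ccc(C#N)c(Cl)c2)n1)Nc1cccc2ccccc12` — "not determined" (no result reported)

Compound 1 reaches only a limit of the assay in an ADME assay on PC-3 cells (Homo sapiens) for cytotoxicity, read by CCK-8 assay, with a stated time of 6 days (on this read-out lower numbers stand for stronger inhibition and higher numbers for weaker inhibition), giving > 30000 nM. Compound 2 has no result in this assay: "not determined" (no result reported). Compound 1 therefore stands at the limit in this assay, since it sits at the limit of > 30000 nM in this assay, at which 1 of the 2 values shown sits. Compound 3 `C[C@@H](Cn1ccc(-c2ccc(C#N)c(Cl)c2)n1)Nc1ncnc2nc[nH]c12` is unmeasured; it differs from compound 1 by a group of 9 heavy atoms (5 carbon, 4 nitrogen; one five-membered aromatic ring with 2 hetero atoms, one six-membered aromatic ring with 2 hetero atoms) in place of a group of 9 heavy atoms (5 carbon, 1 nitrogen, 2 oxygen, 1 sulfur; one six-membered aromatic ring with 1 hetero atom), on an amine nitrogen. Among the compounds with values here, no step between measured compounds is available, so the size of the change is open. Compound 3 is expected to stay near the limit, with an estimated step of a number no higher from compound 1 to compound 3 (the limit leaves the size open) not beyond the scatter. The estimate for compound 3 is 30000 nM, with a range from 3000 nM to 100000 nM.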

Compound 3, half-maximal inhibitory concentration: 14100 nM
The estimate for compound 3 lay 2.1-fold (0.33 log units) above the measured number; low and high end bracket the measured number.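

Replacing (pyridin-3-yl)sulfonyl on the amine nitrogen with the group carrying a five-membered and a six-membered aromatic ring gives an at least 2.1-fold lower number from compound 1 to compound 3 (0.32 log units; beyond the scatter) in this assay. The substituent at this position therefore can shift the read-out into a measurable range. The full size of the step stays open because compound 1 gives only a limit of the assay: the limit of > 30000 nM in this assay, at which 1 of the 3 values shown sits.

Steps involving compound 2 cannot be read. Also open, going by these compounds, is whether loss of the sulfonyl link or the new ring system drives the step, and how a plain acetyl or methyl group at this nitrogen would read.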